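Moving a methoxy group around a methoxybenzyl ring

A few compounds are considered here, and "the series" means these few. Any claim that something is new, unique, unknown or untested is made for them only; others in the source may bear on it.

Of the compounds shown here, three of one series have been tested in a functional assay on HT-29 cells (Homo sapiens) for cytotoxicity, read by MTT assay, with a stated time of 24 h; a lower number here means a stronger inhibitor, a higher number a weaker inhibitor. Compound 1 `c1ccc(CNC(c2ccc[nH]2)c2nnc(-c3ccccc3)o2)cc1` gives 198000 nM. Compound 2 `COc1ccc(-c2nnc(C(NCc3ccccc3)c3ccc[nH]3)o2)cc1` gives 344000 nM, and compound 3 `COc1ccccc1CNC(c1ccc[nH]1)c1nnc(-c2ccccc2)o1` gives 392000 nM. Compound 3 holds the highest of the three numbers, but its distance from compound 2 and from compound 1 stays inside the usual scatter, so none of the three can be set apart from the others.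

Compound 4 `COc1ccc(CNC(c2ccc[nH]2)c2nnc(-c3ccccc3)o2)cc1` has not yet been measured. It keeps the same atoms as compound 3, joined differently: 4-methoxyphenyl in place of 2-methoxyphenyl on a saturated chain carbon bound to an amine nitrogen. For the measured compounds named here, two measured steps bear on this change. Adding a methoxy group to give compound 3 from compound 1 gave a 2.0-fold higher number from compound 1 to compound 3 (0.30 log units; within the scatter), and placing a methoxy group on the other aromatic ring gave a 1.7-fold higher number from compound 1 to compound 2 (0.24 log units; within the scatter). Both steps stayed within the scatter, and compound 4 is simply compound 1 carrying a methoxy group at the 4-position of its benzyl ring, so no step beyond the scatter is expected here. The step from compound 3 to compound 4 is estimated as a 1.3-fold lower number from compound 3 to compound 4 (0.12 log units; within the scatter). Compound 4 is therefore expected to give about 300000 nM, with a range from 150000 nM to 600000 nM.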

Compound 4, half-maximal inhibitory concentration: 286000 nM
For compound 4 the middle estimate is 1.0-fold (0.02 log units) above the measured one; measured number inside the range.
By their numbers in this assay, from the lowest: compounds 1, 4, 2 and 3 (each within the scatter of the next).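

In this assay the change from 2-methoxybenzyl to 4-methoxybenzyl stays within the scatter (a 1.4-fold lower number from compound 3 to compound 4 (0.14 log units; within the scatter)), so these two placements of the methoxy group cannot be told apart in this series. Compound 4 also adds a second comparison with the benzyl ring that carries no methoxy group (a 1.4-fold higher number from compound 1 to compound 4 (0.16 log units; within the scatter)); this step is within the scatter too, so neither compound 3 nor compound 4 can be set apart from compound 1. No measurement at hand speaks to what lies behind these numbers, and these small steps alone offer no explanation.

On these data alone, what stays open is whether any other group on the benzyl ring would give a step beyond the scatter, since these compounds carry only hydrogen or a methoxy group there. A carboxylic acid or a dimethylamino group on that ring, or a longer chain in place of the benzyl group, would show whether this part of the molecule can change the number at all.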